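Shortening the Decyl Chain by One Carbon

A few compounds are considered here, and "the series" means these few. Any claim that something is new, unique, unknown or untested is made for them only; others in the source may bear on it.

Compound 1 `CCCCc1cc2cn([C@H]3C[C@H](O)[C@@H](CO)O3)c(=O)nc2s1` and compound 2 `CCCCCCCCCCc1cc2cn([C@H]3C[C@H](O)[C@@H](CO)O3)c(=O)nc2s1` share one core and differ only in the length of the saturated chain attached to it. In a functional assay on HEL cells (Homo sapiens) for cytotoxicity (on this read-out higher numbers stand for lower toxicity in this test and lower numbers for higher toxicity in this test), compound 1 is reported only as a limit of the assay, > 200000 nM. In this assay compound 2 gives 54000 nM, the only plain number shown among the two. Among the measured compounds shown here, the single measured step, an at least 3.7-fold lower number from compound 1 to compound 2 (0.56 log units; beyond the scatter), rests on a value that sits at the limit of > 200000 nM in this assay, at which 1 of the 2 values shown sits. Compound 3 `CCCCCCCCCc1cc2cn([C@H]3C[C@H](O)[C@@H](CO)O3)c(=O)nc2s1` has not yet been measured; it differs from compound 2 by hydrogen in place of methyl on a saturated chain carbon, nine bonds along the chain from an aromatic carbon. The measured step ran the other way and involved a far longer piece of chain, so it bears only loosely on a one-carbon shortening. The step of a 1.3-fold higher number from compound 2 to compound 3 (0.11 log units; within the scatter) is expected to stay within the scatter. Compound 3 in this assay is estimated at 70000 nM, between 35000 nM and 140000 nM.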

Compound 3, half-maximal cytotoxic concentration: > 20000 nM
Compound 3: no number, only a limit; the forecaster's own chance of this, stated with the estimate: 10%; the middle value does not contradict the limit.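

In this assay compound 3 is reported only as a limit of the assay (> 20000 nM). Its steps from compound 2 and from compound 1 therefore cannot be read. The compounds shown leave open whether hydrogen in place of methyl at this chain end changes the read-out at all.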